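A few compounds are considered here, and "the series" means these few. Any claim that something is new, unique, unknown or untested is made for them only; others in the source may bear on it.

Working notes on the series, read in a functional assay on P388 cells (Mus musculus) for cytotoxicity; a lower number here means a stronger inhibitor, a higher number a weaker inhibitor. Compound 1 `COc1ccc2cc1Oc1ccc(cc1)C[C@H]1C(=O)N(C)[C@@H](C2)C(=O)N[C@H](C)C(=O)N[C@@H](C)C(=O)N(C)[C@@H](Cc2ccccc2)C(=O)N[C@@H](C)C(=O)N1C`, with hydrogen at the aromatic carbon in question, gives 295 nM. Compound 2 `COc1ccc2cc1Oc1ccc(cc1)C[C@H]1C(=O)N(C)[C@@H](C2)C(=O)N[C@H](C)C(=O)N[C@@H](C)C(=O)N(C)[C@@H](Cc2ccc(C)cc2)C(=O)N[C@@H](C)C(=O)N1C` carries methyl there and gives 24 nM. Compound 3 `CCc1ccc(C[C@H]2C(=O)N[C@@H](C)C(=O)N(C)[C@H]3Cc4ccc(cc4)Oc4cc(ccc4OC)C[C@@H](C(=O)N[C@H](C)C(=O)N[C@@H](C)C(=O)N2C)N(C)C3=O)cc1` carries ethyl and gives 9.33 nM, the lowest of the three numbers and clear of the scatter from both others.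

The next analogue is compound 4 `CCCc1ccc(C[C@H]2C(=O)N[C@@H](C)C(=O)N(C)[C@H]3Cc4ccc(cc4)Oc4cc(ccc4OC)C[C@@H](C(=O)N[C@H](C)C(=O)N[C@@H](C)C(=O)N2C)N(C)C3=O)cc1`, which turns 4-ethylphenyl into 4-propylphenyl: methyl in place of hydrogen on a saturated chain carbon, two bonds along the chain from an aromatic carbon.

Within the data shown here, three measured steps bear on this. Methyl on the aromatic carbon gave a 12-fold lower number from compound 1 to compound 2 (1.09 log units; beyond the scatter), and ethyl gave a 32-fold lower number from compound 1 to compound 3 (1.50 log units; beyond the scatter). Among the measured compounds shown here, the closest precedent is the single chain extension so far, a 2.6-fold lower number from compound 2 to compound 3 (0.41 log units; beyond the scatter), which is modest and smaller than the first step. Across these three compounds the number falls with each added carbon, and none goes against that. For the measured compounds named here, no measured compound yet tests a chain of this length, so a halt or reversal stays open.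

A small further fall is expected, probably not clear of the scatter. The expected step is a 1.3-fold lower number from compound 3 to compound 4 (0.12 log units; within the scatter). For compound 4 the estimate is 7 nM, with an expected range of 2.5 nM to 22 nM.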

Compound 4, half-maximal inhibitory concentration: 25.7 nM
Beside the measured number, compound 4's estimate is 3.7-fold (0.56 log units) below it, and the stated range ends below it.
By their numbers in this assay, from the lowest: compound 3; then compounds 2 and 4 (each within the scatter of the next); then compound 1.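

At this position in this assay the run of falling numbers ends once the chain passes ethyl, with a 2.8-fold higher number from compound 3 to compound 4 (0.44 log units; beyond the scatter), so the trend seen through compound 1, compound 2 and compound 3 does not extend to 4-propylphenyl, and compound 4 goes against it. Ethyl now stands as the lowest point among the chains in hand, while methyl and propyl cannot be told apart, with a 1.1-fold higher number from compound 2 to compound 4 (0.03 log units; within the scatter). The added methyl costs only part of what the alkyl groups gain over hydrogen, since propyl on the aromatic carbon still gives an 11-fold lower number from compound 1 to compound 4 (1.06 log units; beyond the scatter), which places all three alkyl groups clear of the unsubstituted compound.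

Nothing available accounts for the upturn after ethyl. From the compounds shown here alone, whether a butyl chain would continue the rise, and whether a branched isopropyl group or an amine at the end of the chain would read nearer to ethyl or to propyl, stays open, and the turn itself rests on compound 4 alone.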